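The compounds below may be only part of what the source reports. "The series", "measured", "known", "first", "only" and "open" are said of these compounds alone.

In a functional assay on A549 cells (Homo sapiens) for inhibition, read by colorimetric assay and MTT assay, with a stated time of 72 h (on this read-out lower numbers stand for stronger inhibition and higher numbers for weaker inhibition), compound 1 `Cn1c2cnc1OCCCCCCCCCCOc1cc3ccccc3cc1-2` gives 20000 nM. Compound 2 `CCCCCCOc1ncc(-c2ccccc2OC)n1C` gives 37000 nM, a number within the usual scatter of compound 1, so the two cannot be told apart on this read-out. Compound 3 `C=CCCOc1ncc(-c2ccccc2OC)n1C` differs from compound 2 in one place: vinyl in place of butyl on a saturated chain carbon, two bonds along the chain from an oxygen on an aromatic ring. It has vinyl in place of butyl on a saturated chain carbon, two bonds along the chain from an oxygen on an aromatic ring, so hexyloxy becomes (but-3-en-1-yl)oxy. Within the data shown here, compound 1 and compound 2 differ in more than one place, so no measured step bears on this change. The expectation therefore starts from compound 2 at 37000 nM. The step expected in this assay is a 1.2-fold higher number from compound 2 to compound 3 (0.09 log units; within the scatter), a small move towards weaker inhibition that stays within the scatter. Compound 3 is estimated at 45000 nM, with an expected range from 20000 nM to 100000 nM.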

Compound 3, half-maximal inhibitory concentration: 22000 nM
The estimate for compound 3 lay 2.0-fold (0.31 log units) above the measured number; low and high end bracket the measured number.
By their numbers in this assay, from the lowest: compounds 1, 3 and 2 (each within the scatter of the next).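

In this assay the change from hexyloxy to (but-3-en-1-yl)oxy gives a 1.7-fold lower number from compound 2 to compound 3 (0.23 log units; within the scatter) and so cannot be told apart from no change at all. Among these compounds, this is the first reading at this saturated chain carbon, two bonds along the chain from an oxygen on an aromatic ring, and it shows that vinyl can stand in place of butyl, with fewer heavy atoms and a double bond outside aromatic rings, without a measurable shift on this read-out. Nothing available bears on the reason for this result. As far as these compounds go, whether any group at this place can move the number beyond the scatter remains open. An amine or a carboxylic acid in place of the vinyl, or a chain longer than hexyl, would be needed to settle that.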